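Lengthening the amine substituent on a tracheal relaxant series

The source may report more compounds than this note shows. Statements on the series, on what has been measured and on what is new or still open speak of the compounds shown alone.

Of the compounds shown here, three sharing one core have been tested in a functional assay on trachea (Cavia porcellus); on this read-out higher numbers stand for weaker inhibition and lower numbers for stronger inhibition. Compound 1 `CCN1CC[C@@]2(OC)OC(N)=C(C#N)[C@@H](c3ccc(Cl)cc3)[C@@H]2C1` gives 14900 nM. Within the data shown here, compound 2 `CCN1CC[C@@]2(OC)OC(N)=C(C#N)[C@@H](c3ccc(OC)cc3)[C@@H]2C1` gives 25500 nM; the single step recorded between them, a 1.7-fold higher number from compound 1 to compound 2 (0.23 log units; within the scatter), stays inside the scatter of the measurement. Compound 3 `CO[C@@]12CCN(C)C[C@H]1[C@H](c1ccc(-c3cccs3)cc1)C(C#N)=C(N)O2` gives 13800 nM, the lowest of the three numbers, yet it lies within the scatter of both compound 1 and compound 2, so no ranking among the three can be claimed.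

Compound 4 `CCN1CC[C@@]2(OC)OC(N)=C(C#N)[C@@H](c3ccc(-c4cccs4)cc3)[C@@H]2C1` differs from compound 3 by methyl in place of hydrogen on a saturated chain carbon bound to an amine nitrogen in a ring. Among the measured compounds shown here, no measured step touches this change: the only recorded step concerns a substituent on the aromatic ring, not the group on the ring amine nitrogen, and it was itself inside the scatter. Compounds 1 and 2 carry the ethyl group that compound 4 would carry, and their numbers sit within the scatter of compound 3, which suggests the amine substituent has no effect that this assay can resolve. The step of a 1.1-fold lower number from compound 3 to compound 4 (0.03 log units; within the scatter) is therefore expected to be none beyond the scatter. Compound 4 is estimated at 13000 nM, with a likely range from 6000 nM to 30000 nM.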

Compound 4, half-maximal inhibitory concentration: 19800 nM
The estimate for compound 4 lay 1.5-fold (0.18 log units) below the measured number, within the range that was stated.
By their numbers in this assay, from the lowest: compounds 3, 1, 4 and 2 (each within the scatter of the next).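

In this assay, the move from methyl to ethyl on the ring amine nitrogen gives a 1.4-fold higher number from compound 3 to compound 4 (0.16 log units; within the scatter). Among these compounds, this is the first direct reading of that position, and it shows that with thiophen-2-yl held fixed on the aromatic ring, the added carbon makes no difference that this assay can resolve. With the ethyl group held fixed, the aromatic substituent also stays inside the scatter: thiophen-2-yl in place of methoxy gives a 1.3-fold lower number from compound 2 to compound 4 (0.11 log units; within the scatter), and thiophen-2-yl in place of chloro gives a 1.3-fold higher number from compound 1 to compound 4 (0.12 log units; within the scatter). Nothing available here helps explain these numbers.

Methyl and ethyl are the only groups shown on the ring amine nitrogen, so it remains open whether a longer chain such as butyl, or a benzyl group, would move the number beyond the scatter. As far as these compounds go, it is also open whether an amine or a carboxylic acid on the aromatic carbon would separate from the chloro, methoxy and thiophen-2-yl compounds.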